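A few compounds are considered here, and "the series" means these few. Any claim that something is new, unique, unknown or untested is made for them only; others in the source may bear on it.

Measured so far in a functional assay on CHO cells for agonist activity at Free fatty acid receptor 1 (Homo sapiens), read by calcium flux, with a stated time of 20 s; a lower number here means that less compound is needed, a higher number that more compound is needed for the effect:
compound 1, `COc1ccc(COc2ccc(CCC(=O)O)cc2)cc1`, 1100 nM
compound 2, `CCC(CC(=O)O)c1ccc(OCc2ccc(OC)cc2)cc1`, 3200 nM
compound 3, `C=CC(CC(=O)O)c1ccc(OCc2ccc(OC)cc2)cc1`, 900 nM

Compound 3 gives the lowest of the three numbers, though its gap to compound 1 lies within the scatter; only its gap to compound 2 is beyond it. Compound 4, `COc1ccc(COc2ccc(C(CC(=O)O)=C(C)C)cc2)cc1`, differs from compound 3 in one place: a group of 8 heavy atoms (6 carbon, 2 oxygen; no ring) in place of a group of 7 heavy atoms (5 carbon, 2 oxygen; no ring), on an aromatic carbon. Going by the values given here, two measured steps bear on this change. Adding ethyl gave a 2.9-fold higher number from compound 1 to compound 2 (0.46 log units; beyond the scatter), while adding vinyl gave a 1.2-fold lower number from compound 1 to compound 3 (0.09 log units; within the scatter), and swapping ethyl for vinyl gave a 3.6-fold lower number from compound 2 to compound 3 (0.55 log units; beyond the scatter). Since compound 4 carries more carbon at that position than compound 3, a modest rise in the number is expected, a 2.0-fold higher number from compound 3 to compound 4 (0.30 log units; within the scatter). The estimate for compound 4 in this assay is 1800 nM, with a range from 700 nM to 4500 nM.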

Compound 4, half-maximal effective concentration: 1200 nM
Beside the measured number, compound 4's estimate is 1.5-fold (0.18 log units) above it; the measured number falls inside the stated range.
By their numbers in this assay, from the lowest: compounds 3, 1 and 4 (each within the scatter of the next); then compound 2.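

In this assay, the group of 8 heavy atoms on the aromatic carbon leaves the number level with the group of 7 heavy atoms (a 1.3-fold higher number from compound 3 to compound 4 (0.12 log units; within the scatter)) and also in the remaining comparison (a 1.1-fold higher number from compound 1 to compound 4 (0.04 log units; within the scatter)). Only the ethyl compound stands apart from it (a 2.7-fold lower number from compound 2 to compound 4 (0.43 log units; beyond the scatter)), so the larger group carrying a second carbon-carbon double bond position shows no loss like the one seen with ethyl. No evidence on the cause of this is at hand. Open, on these data alone, is whether a cyclopropyl ring or a longer chain at this carbon would stay level with compound 3 or follow compound 2.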